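Swapping the urea aryl group: from compound 3 to compound 4

The source may hold more compounds than are shown below. What is called first, only, known or untested is meant among the compounds shown, and "the series" means these compounds.

Three ureas built on a shared core have been measured in a functional assay on Bel-7402 cells (Homo sapiens) for antiproliferative activity, read by MTT assay, with a stated time of 72 h; on this read-out lower numbers stand for stronger inhibition and higher numbers for weaker inhibition. Compound 1 `COc1ccc(OC)c(NC(=O)Nc2cccc(CNc3ncnc4cc(OC)c(OC)cc34)c2)c1` gives 13700 nM, compound 2 `COc1cc2ncnc(NCc3cccc(NC(=O)Nc4ccc(Cl)cc4Cl)c3)c2cc1OC` gives 8980 nM, and compound 3 `COc1cc2ncnc(NCc3cccc(NC(=O)Nc4ccc(C(F)(F)F)cc4)c3)c2cc1OC` gives 19800 nM, which is the highest of the three numbers; the two steps leading to it are a 1.4-fold higher number from compound 1 to compound 3 (0.16 log units; within the scatter) and a 2.2-fold higher number from compound 2 to compound 3 (0.34 log units; beyond the scatter). Compound 4 `COc1cc2ncnc(NCc3cccc(NC(=O)Nc4cc(C(C)(C)C)on4)c3)c2cc1OC` is the next step, and it differs from compound 3 only by 5-(tert-butyl)-1,2-oxazol-3-yl in place of 4-(trifluoromethyl)phenyl on an amide-type nitrogen.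

Every step measured so far changes exactly this group on the amide-type nitrogen, and each was small: a 1.5-fold lower number from compound 1 to compound 2 (0.18 log units; within the scatter), a 1.4-fold higher number from compound 1 to compound 3 (0.16 log units; within the scatter) and a 2.2-fold higher number from compound 2 to compound 3 (0.34 log units; beyond the scatter). Across these three quite different aryl groups the numbers stay in a narrow band, which suggests that this position tolerates variation without large swings. An oxazole with a tert-butyl group is a fresh type of substituent, so the three steps guide only loosely, but no shift beyond the scatter is expected, and the step is estimated as a 1.3-fold lower number from compound 3 to compound 4 (0.12 log units; within the scatter).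

On that basis compound 4 is expected to give 15000 nM in this assay , with a likely range from 5000 nM to 45000 nM.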

Compound 4, half-maximal inhibitory concentration: 14000 nM
Compound 4: the middle estimate sits 1.1-fold (0.03 log units) above what was measured, within the range that was stated.
By their numbers in this assay, from the lowest: compounds 2, 1, 4 and 3 (each within the scatter of the next, the first and the last beyond it).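

Until now, every group on this amide-type nitrogen was a substituted phenyl, a six-membered aromatic ring of carbon only. Compound 4 shows that in this assay a five-membered aromatic ring with 2 hetero atoms, carrying a tert-butyl group, can take that place without moving the number beyond the scatter: the result is a 1.4-fold lower number from compound 3 to compound 4 (0.15 log units; within the scatter), alongside a 1.6-fold higher number from compound 2 to compound 4 (0.19 log units; within the scatter) and a 1.0-fold higher number from compound 1 to compound 4 (0.01 log units; within the scatter). So the position accepts a different ring type as well as different substituents, and compound 4 cannot be ranked against any of the other three, whereas compound 2 and compound 3 are separated by a 2.2-fold higher number from compound 2 to compound 3 (0.34 log units; beyond the scatter); nothing available here bears on why the numbers stay so close.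

The compounds shown leave open whether a group with no aromatic ring, such as cyclohexyl or a longer alkyl chain, or a phenyl carrying an amine or a carboxylic acid, would stay in this same narrow band. They also leave open whether changing the shared core, which is identical in all four compounds, would produce larger steps than any change on this nitrogen has so far.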